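The source may report more compounds than this note shows. Statements on the series, on what has been measured and on what is new or still open speak of the compounds shown alone.

Measured so far: compound 1 `Cc1ccc2[nH]c(=O)c(CN(Cc3ccc(C(C)(C)C)cc3)C(C)c3ccc(F)cc3)cc2c1` and compound 2 `Cc1ccc2[nH]c(=O)c(CN(Cc3ccc(C(C)(C)C)cc3)C(C)c3ccc(OC(F)F)cc3)cc2c1`.

In a toxicity assay on MDCK cells (Canis lupus familiaris) for cytotoxicity, read by crystal violet staining, with a stated time of 48 h (on this read-out lower numbers stand for higher toxicity in this test and higher numbers for lower toxicity in this test), compound 1 gives > 33000 nM, a limit of the assay rather than a number. In this assay compound 2 gives > 5000 nM, again only a limit. The step that the two limits leave unreadable from compound 1 to compound 2 runs from one limit of > 33000 nM in this assay, at which 1 of the 2 values shown sits, to another the limit of > 5000 nM in this assay, at which 1 of the 2 values shown sits, and so cannot be sized. Compound 3 `Cc1ccc2[nH]c(=O)c(CN(Cc3ccc(C(C)(C)C)cc3)Cc3ccc(N(C)C)c(Cl)c3)cc2c1` differs from compound 2 by 3-chloro-4-(dimethylamino)benzyl in place of 1-(4-(difluoromethoxy)phenyl)ethyl on an amine nitrogen. Going by the values given here, no measured step bears on this change, and no shift beyond the scatter is expected in this assay, so the estimated step that the limit leaves unreadable from compound 2 to compound 3 is flat. Compound 3 is therefore expected to give 20000 nM, within 5000 nM to 80000 nM.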

Compound 3, half-maximal cytotoxic concentration: > 10000 nM
Compound 3 gave a limit, no number; the forecaster's own chance of this, stated with the estimate: 70%; the middle value is on the limit's open side.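

Going by these compounds alone, compound 1, compound 2 and compound 3 all stand at limits of the assay, and no step between them can be read. The compounds shown leave open where any of their half-maximal cytotoxic concentrations lies in this assay, and whether the groups exchanged on the amine nitrogen shift it.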